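Swapping iodo for fluoro on a thiosemicarbazone

A few compounds are considered here, and "the series" means these few. Any claim that something is new, unique, unknown or untested is made for them only; others in the source may bear on it.

Measured compounds:
compound 1, `CC(=NNC(=S)Nc1ccc(I)cc1)c1ccccn1`, 64 nM
compound 2, `CC(=NNC(=S)Nc1ccccc1[N+](=O)[O-])c1ccccn1`, 6.6 nM
compound 3, `CC(=NNC(=S)Nc1cccc([N+](=O)[O-])c1)c1ccccn1`, 140 nM

Of the compounds shown here, three sharing one core have been tested in a functional assay on T98G cells (Homo sapiens) for cytotoxicity, read by MTT assay, with a stated time of 48 h; a higher number here means a weaker inhibitor, a lower number a stronger inhibitor. Compound 1 stands second highest of the three numbers. Its nearest neighbour is compound 3, whose number is higher by a gap that lies beyond the usual scatter, so compound 3 is the weaker of the two. Furthest away is compound 2, which gives a much lower number and is clearly the strongest of the three.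

Compound 4, `CC(=NNC(=S)Nc1ccc(F)cc1)c1ccccn1`, has not yet been measured. It differs from compound 1 in one place: fluoro in place of iodo on an aromatic carbon. Both groups are single atoms without charge, donors or acceptors, sitting at the same aromatic carbon, para to a large group. Among the compounds with values here, no measured pair shows this exact swap, so its effect is not known from these data. A small step from compound 1 to compound 4 is expected, toward a slightly higher number if anything, and likely within the scatter: a 1.6-fold higher number from compound 1 to compound 4 (0.19 log units; within the scatter). Compound 4 is estimated at 100 nM, with a range from 30 nM to 400 nM.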

Compound 4, half-maximal inhibitory concentration: 17 nM
For compound 4 the middle estimate is 5.9-fold (0.77 log units) above the measured one, outside the stated range (below it).
By their numbers in this assay, from the lowest: compound 2; then compound 4; then compound 1; then compound 3.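

Fluoro in place of iodo on this aromatic carbon gives a 3.8-fold lower number from compound 1 to compound 4 (0.58 log units; beyond the scatter) in this assay and so shows that the choice of halogen here changes the result. Within the data shown here, this is the first reading of a single change at this position, and it shows that swapping one single-atom group for another can move the number beyond the scatter, even though the count of hydrogen-bond donors and acceptors and the net charge stay the same. No supporting measurement bears on what lies behind this shift.

On these data alone, whether chloro or bromo on the same carbon would give a number between those of compound 1 and compound 4 remains open. As far as these compounds go, it is also open whether a non-halogen group there, such as a methoxy group or an amine, would match fluoro or iodo.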